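The source may hold more compounds than are shown below. What is called first, only, known or untested is meant among the compounds shown, and "the series" means these compounds.

In a functional assay on A549 cells (Homo sapiens) for cytotoxicity (on this read-out higher numbers stand for weaker inhibition and lower numbers for stronger inhibition), compound 1 `Cc1ccc(C2CN(S(=O)(=O)c3ccccc3)C(=O)N2)cc1` gives > 316000 nM, which is a limit of the assay and not a number. Its place on the scale is the limit of > 316000 nM in this assay, at which 1 of the 3 values shown sits. Compound 3 `O=C1NC(c2ccccc2)CN1S(=O)(=O)c1ccccc1` gives 145000 nM, and compound 2 `O=C1NC(c2ccc(Br)cc2)CN1S(=O)(=O)c1ccc2c(c1)CCC2` gives 33900 nM and differs in more than one place. Compound 4 `Cc1ccc(C2CN(S(=O)(=O)c3ccc(Cl)cc3)C(=O)N2)cc1` changes compound 1 by chloro in place of hydrogen on an aromatic carbon, turning phenyl to 4-chlorophenyl. No measurement covers this exact change. The nearest evidence is an at least 2.1-fold lower number from compound 1 to compound 3 (0.33 log units; beyond the scatter), a change in a different place, so only a modest move towards lower numbers is expected. The expected change is an at least 2.6-fold lower number from compound 1 to compound 4 (0.42 log units; beyond the scatter). For compound 4 the estimated value is 120000 nM, with an expected range of 40000 nM to 316000 nM.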

Compound 4, half-maximal inhibitory concentration: 158000 nM
Compound 4: middle estimate off by 1.3-fold (0.12 log units), on the low side, within the range that was stated.
By their numbers in this assay, from the lowest: compound 2; then compounds 3 and 4 (each within the scatter of the next). At a limit, above all of these: compound 1.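

Turning phenyl to 4-chlorophenyl, with chloro para to a large group, gives in this assay an at least 2.0-fold lower number from compound 1 to compound 4 (0.30 log units; that floor lies within the scatter). This is the first step shown on this aromatic ring, as the earlier step changed the methyl on the other one, and compound 4 gives a number. Compound 1 has only a limit, so the true size of the step stays unknown: the limit of > 316000 nM in this assay, at which 1 of the 4 values shown sits.

From the compounds shown here alone, whether an amine, a carboxylic acid or a methoxy group at this place would give a similar number remains open. So does whether chloro would have the same effect without the methyl.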